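The compounds below may be only part of what the source reports. "The series", "measured", "known", "first", "only" and "open" are said of these compounds alone.

The measured compounds, each with its result in a functional assay on NCI-H226 cells (Homo sapiens) for inhibition, read by sulforhodamine B assay, with a stated time of 48 h, tested at 10 uM; a higher number here means a weaker effect of the compound at the concentration tested, a lower number a stronger effect:

Compound 1, `O=C(Nc1cccc(-n2cc(-c3ccncc3)c(-c3cc(O)cc(Cl)c3)n2)c1)Nc1ccc(Cl)c(C(F)(F)F)c1`, gives 41.2%.
Compound 2, `COc1cc(Cl)cc(-c2nn(-c3cccc(NC(=O)Nc4ccc(Cl)c(C(F)(F)F)c4)c3)cc2-c2ccncc2)c1`, gives -2.82%.
Compound 3, `COc1cc(Cl)cc(-c2nn(-c3cccc(NC(=O)Nc4cc(C(F)(F)F)cc(C(F)(F)F)c4)c3)cc2-c2ccncc2)c1`, gives -5.97%.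

Compound 2 sits among the low numbers, close to compound 3 (within the scatter) and far from compound 1 (beyond the scatter). Among the compounds with values here, the only step joining two measured compounds that differ in one place is a number 44 percentage points lower from compound 1 to compound 2 (beyond the scatter), a methyl in place of hydrogen on an oxygen on an aromatic ring. Compound 4, `COc1cc(Cl)cc(-c2nn(-c3cccc(NC(=O)c4cccc(C(F)(F)F)c4)c3)cc2-c2ccncc2)c1`, is not yet measured; it differs from compound 2 in this way: 3-(trifluoromethyl)phenyl in place of (4-chloro-3-(trifluoromethyl)phenyl)amino on a carbonyl carbon. Within the data shown here, no measured step touches the carbonyl carbon or the group on it, so this change has no direct precedent. Compound 2 and compound 3 carry different groups at the same end of the molecule, and their values lie within the scatter of each other, which weakly suggests that this end tolerates change. Compound 4 is therefore expected to stay near compound 2, with an expected step of a number 7.8 percentage points higher from compound 2 to compound 4 (within the scatter), not beyond the scatter. The estimate for compound 4 is 5%, between -12% and 30%.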

Compound 4, a percentage reported as activity, at one concentration (the size of the read-out at that concentration, not a potency): 69%
Compound 4: middle estimate off by 64 percentage points, on the low side, and the stated range ends below it.
By their numbers in this assay, from the lowest: compounds 3 and 2 (each within the scatter of the next); then compound 1; then compound 4.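

The group on the carbonyl carbon matters far more than compound 2 and compound 3 suggested: those two both keep an aryl amino group there, and their values lie within the scatter of each other. In this assay, replacing (4-chloro-3-(trifluoromethyl)phenyl)amino with 3-(trifluoromethyl)phenyl gives a number 71.8 percentage points higher from compound 2 to compound 4 (beyond the scatter), so the effect at the concentration tested becomes much weaker. This single swap removes both the amino nitrogen, with its hydrogen-bond donor, and the chlorine, and nothing measured here explains the change.

The compounds shown leave open which of these two losses accounts for the step. A (3-(trifluoromethyl)phenyl)amino group, or a 4-chloro-3-(trifluoromethyl)phenyl group on the carbonyl carbon, would each alter only one of them.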